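Swapping One Aromatic Ring on Compound 3

The compounds below may be only part of what the source reports. "The series", "measured", "known", "first", "only" and "open" are said of these compounds alone.

Measured in a functional assay on A-375 cells (Homo sapiens) for antiproliferative activity; a lower number here means a stronger inhibitor, a higher number a weaker inhibitor:
- Compound 1 `O=C(Nc1ccc(-c2cscn2)cc1)C1CCCN(C(=O)c2ccc(F)c(F)c2)C1` gives > 20000 nM as a limit of the assay, not a number
- Compound 2 `O=C(Nc1ccc(-c2cscn2)cc1)C1CCCN(Cc2cc(F)c(F)c(F)c2)C1` gives 400 nM in the same test
- Compound 3 `O=C(Nc1ccc(-c2cccnc2)cc1)C1CCCN(Cc2ccc(F)c(F)c2)C1` gives 610 nM in the same test

Compound 3 lies within the scatter of compound 2, so the two cannot be told apart. Compound 4 `O=C(Nc1ccc(-c2ccoc2)cc1)C1CCCN(Cc2ccc(F)c(F)c2)C1` has furan-3-yl in place of pyridin-3-yl on an aromatic carbon and is otherwise unchanged. For the measured compounds named here, the only measured step is large, an at least 50-fold lower number from compound 1 to compound 2 (1.69 log units; beyond the scatter), but it concerns a group on an amine nitrogen in a ring, elsewhere in the molecule. Going by the values given here, no measured step touches the group changed here, so no shift beyond the scatter is expected. The expected change is a 1.2-fold lower number from compound 3 to compound 4 (0.09 log units; within the scatter) and stays within the scatter. In this assay compound 4 is estimated at 500 nM with an expected range from 150 nM to 1700 nM and no narrower claim.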

Compound 4, half-maximal inhibitory concentration: 1290 nM
The estimate for compound 4 lay 2.6-fold (0.41 log units) below the measured number; measured number inside the range.
By their numbers in this assay, from the lowest: compounds 2 and 3 (each within the scatter of the next); then compound 4. At a limit, above all of these: compound 1.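

Furan-3-yl in place of pyridin-3-yl gives a 2.1-fold higher number from compound 3 to compound 4 (0.33 log units; beyond the scatter) in this assay, the first measured change at this position, para to a large group. The number therefore responds to the aromatic ring placed here, although the step is modest. Nothing measured here accounts for this shift.

On these data alone, compound 3 and compound 4 differ in both ring size and hetero atom, so the share of each in the step remains open. As far as these compounds go, how a plain phenyl ring or a thiophene ring would fare at this position also remains open.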